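Swapping Trifluoromethyl for Chloro on a Second Core

A few compounds are considered here, and "the series" means these few. Any claim that something is new, unique, unknown or untested is made for them only; others in the source may bear on it.

Compound 1 `Cc1cccc(C(=O)Nc2ccc3c(c2)CC(CNS(C)(=O)=O)C3)c1-c1ccc(C(F)(F)F)cc1` and compound 2 `Cc1cccc(C(=O)Nc2ccc3c(c2)CC(CNS(C)(=O)=O)C3)c1-c1ccc(Cl)cc1` are built on one shared core, while compound 3 `COC(=O)NC1CCc2ccc(NC(=O)c3cccc(C)c3-c3ccc(C(F)(F)F)cc3)cc2CC1` and compound 4 `COC(=O)NC1CCc2ccc(NC(=O)c3cccc(C)c3-c3ccc(Cl)cc3)cc2CC1` are built on another. The difference between the two cores is not broken down here. In an assay for inhibition of apolipoprotein B-100 (Homo sapiens), tested at 100 nM (a lower number here means a stronger inhibitor, a higher number a weaker inhibitor), compound 1 gives 6.5 nM, and compound 2 gives 16 nM. The step between them, a 2.5-fold higher number from compound 1 to compound 2 (0.39 log units; beyond the scatter), goes with one structural change: chloro in place of trifluoromethyl on an aromatic carbon. On the second core, compound 3 gives 1.6 nM in this assay, the lowest of the three measured numbers. Compound 4 carries the matching change on this core: chloro in place of trifluoromethyl on an aromatic carbon. The surroundings of the change read the same in both pairs, so it is the same change. Going by the values given here, the only measured example of it is the step of a 2.5-fold higher number from compound 1 to compound 2 (0.39 log units; beyond the scatter), and the expectation for compound 4 rests on that step alone. A step of about the same size is expected on the second core, a 2.5-fold higher number from compound 3 to compound 4 (0.40 log units; beyond the scatter). With a single example, a somewhat larger or smaller step cannot be ruled out. Compound 4 is therefore expected to give 4 nM in this assay, most likely between 2 nM and 8 nM. Whether that holds is what the measurement will show.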

Compound 4, half-maximal inhibitory concentration: 2 nM
Compound 4: middle estimate off by 2.0-fold (0.30 log units), on the high side, and the stated range covers the measured number.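

On the core of compound 3, chloro in place of trifluoromethyl gives a 1.3-fold higher number from compound 3 to compound 4 (0.10 log units; within the scatter), so in this assay these two compounds cannot be told apart. Set beside the same change on the core of compound 1, where the step lies beyond the scatter, the new step does not differ from it by more than two such steps can differ by chance: the same change on two cores in this assay, a 2.5-fold higher number (0.39 log units; beyond the scatter) from compound 1 to compound 2 and a 1.3-fold higher number (0.10 log units; within the scatter) from compound 3 to compound 4, 2.0-fold (0.29 log units) apart, within the scatter of two such steps This shows that the change can be carried from one of these cores to the other without a detectable difference in step size, but with one pair on each core it does not establish that the steps are truly equal, nor does it show that the same would hold on any further core.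

The compounds shown carry only trifluoromethyl and chloro at this place on the aromatic ring, so how a methyl, a methoxy or a nitrile there would read in this assay remains open. Also open is which part of the difference between the two cores goes with their different numbers, since no pair shown isolates a single change between them.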